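Swapping the benzyl arm of compound 3 for an anilino arm

The source may report more compounds than this note shows. Statements on the series, on what has been measured and on what is new or still open speak of the compounds shown alone.

For the measured compounds named here, compound 3, `CN1CCN(c2ccc(Nc3ncc(Cl)c(NCc4ccc(C(F)(F)F)cc4)n3)nc2)CC1`, is the only member of this small set that returns a number: in a functional assay on MDA-MB-231 cells (Homo sapiens) for inhibition, read by CCK-8 assay, with a stated time of 48 h (a lower number here means a stronger inhibitor of growth, a higher number a weaker inhibitor of growth), compound 3 gives 19100 nM. The two other compounds return limits. Compound 1, `Cc1ccccc1Nc1nc(Nc2ccccc2)ncc1Cl`, gives > 100000 nM in this assay, which is a limit of the assay rather than a number. Compound 2, `Cc1ccccc1Nc1nc(NCc2ccccc2)ncc1Cl`, gives > 100000 nM in this assay, again a limit. Going by the values given here, the step that the two limits leave unreadable from compound 1 to compound 2 is therefore unreadable, and the only thing these two compounds show is the limit of > 100000 nM in this assay, at which 2 of the 3 values shown sit.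

Compound 4, `CC(C)c1ccc(Nc2nc(Nc3ccc(N4CCN(C)CC4)cn3)ncc2Cl)cc1`, differs from compound 3 by 4-isopropylphenyl in place of 4-(trifluoromethyl)benzyl on a nitrogen on an aromatic ring. Among the compounds with values here, the one measured step that touches the same nitrogen, a step that the two limits leave unreadable from compound 1 to compound 2, runs between two limits and gives no readable size, so there is no precedent in this set for the size or direction of the change in this assay. With nothing to read from, the expectation for compound 4 is taken to stay close to compound 3, and the step of a 1.9-fold lower number from compound 3 to compound 4 (0.28 log units; within the scatter) is estimated to lie within the usual scatter. Compound 4 is accordingly expected to give about 10000 nM in this assay, with a range from 2000 nM to 60000 nM.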

Compound 4, concentration for 50% growth inhibition: 7020 nM
The estimate for compound 4 lay 1.4-fold (0.15 log units) above the measured number; low and high end bracket the measured number.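

For the compounds shown here, on a nitrogen on an aromatic ring, putting 4-isopropylphenyl in place of 4-(trifluoromethyl)benzyl gives the first readable step in this assay, a 2.7-fold lower number from compound 3 to compound 4 (0.43 log units; beyond the scatter). The change is modest, yet it shows that this place can move the number and that a benzyl arm is not needed there for a measurable value. Compounds 1 and 2 could not show this, as both remain limits of the assay rather than numbers: the limit of > 100000 nM in this assay, at which 2 of the 4 values shown sit.

The single step changes the arm's link and its ring substituent together, so the compounds shown cannot separate the two, and 4-(trifluoromethyl)phenyl or 4-isopropylbenzyl on this nitrogen would be needed to do so. Also open, as far as these compounds go, is how an amine or a carboxylic acid on that ring would read.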